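Moving the hydroxyl-bearing arm on the outer phenyl ring

The source may hold more compounds than are shown below. What is called first, only, known or untested is meant among the compounds shown, and "the series" means these compounds.

Compound 1 `O=C(O)CC/C=C\CO[C@H]1C(OCc2ccc(-c3ccc(CO)cc3)cc2)CC[C@@H]1N1CCCCCC1`: 20 nM
Compound 2 `O=C(O)CC/C=C\CO[C@H]1[C@@H](OCc2ccc(-c3ccc(CO)cc3)cc2)CC[C@@H]1N1CCCCCC1`: 50.1 nM
Compound 3 `O=C(O)CC/C=C\CO[C@H]1[C@@H](OCc2ccc(-c3ccccc3)cc2)CC[C@@H]1N1CCCCC1`: 31.6 nM; 50.1 nM (2 entries)

In a functional assay for antagonist activity at thromboxane A2 receptor (Rattus norvegicus) (on this read-out higher numbers stand for weaker binding and lower numbers for tighter binding), compound 1 gives the lowest of the two single numbers; compound 2 differs only in that one stereocentre at a saturated ring carbon is drawn with a configuration, and the step of a 2.5-fold higher number from compound 1 to compound 2 (0.40 log units; beyond the scatter) lies beyond the scatter. Compound 3, with its repeated entries (the several entries of compound 3 in this assay, 31.6 nM; 50.1 nM (2 entries)), shows how far repeats of the same compound can spread. Compound 4 `O=C(O)CC/C=C\CO[C@H]1C(OCc2ccc(-c3ccccc3CCO)cc2)CC[C@@H]1N1CCCCCC1` carries the change (2-(2-hydroxyethyl)phenyl in place of 4-(hydroxymethyl)phenyl on an aromatic carbon). Within the data shown here, no measured step touches this part of the molecule, so only a small move in either direction is expected. Compound 4 is therefore estimated at 32 nM (range 10 nM to 100 nM), a step of a 1.6-fold higher number from compound 1 to compound 4 (0.20 log units; within the scatter) that is expected to stay close to the scatter.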

Compound 4, dissociation constant: 31.6 nM
Beside the measured number, compound 4's estimate is 1.0-fold (0.01 log units) above it; the range from low to high includes it.
By their numbers in this assay, from the lowest: compounds 1, 4 and 2 (each within the scatter of the next, the first and the last beyond it).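

In this assay, putting 2-(2-hydroxyethyl)phenyl in place of 4-(hydroxymethyl)phenyl gives a 1.6-fold higher number from compound 1 to compound 4 (0.20 log units; within the scatter). Among these compounds, this position, on an aromatic carbon para to a large group, therefore accepts this swap of the hydroxyl-bearing arm with no step that stands out from the scatter. Compound 4 shares with compound 1 the ring carbon drawn without a configuration, so this step is free of the stereo difference in the earlier pair: the fact that one of compounds 1 and 2 is drawn with a defined configuration and the other without, at the place where they differ

The change alters the arm's place and length together, and the two cannot be separated here. Going by these compounds, whether a carboxylic acid or an amine at the end of the arm would fare the same remains open.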